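This account rests on a few compounds, and the source may have more. Where it says the series, first, only, none or still open, it means among the compounds named here.

Working notes on the series.

Compound 1 `CCCCCCC[C@H]1C[C@H](Cl)CCN1S(=O)(=O)c1ccc(C)cc1` gives 54000 nM in a functional assay on WiDr cells (Homo sapiens) for antiproliferative activity, read by sulforhodamine B assay, with a stated time of 48 h; on this read-out higher numbers stand for weaker inhibition of growth and lower numbers for stronger inhibition of growth. Compound 2 `Cc1ccc(S(=O)(=O)N2CC[C@@H](Cl)C[C@@H]2C2CCCCC2)cc1` gives 15000 nM in this assay. The change between them is cyclohexyl in place of heptyl on a saturated ring carbon, and it produced a 3.6-fold lower number from compound 1 to compound 2 (0.56 log units; beyond the scatter). Compound 3 `CCCCCCCC1C=C(Cl)CCN1S(=O)(=O)c1ccc(C)cc1` gives 50000 nM in this assay; against compound 1 the two values lie within the usual scatter, and the difference between the two cores is not broken down here. Compound 4 `Cc1ccc(S(=O)(=O)N2CCC(Cl)=CC2C2CCCCC2)cc1` is not yet measured in this assay. From compound 3 to compound 4 the change is cyclohexyl in place of heptyl on a saturated ring carbon, the same kind of change as that from compound 1 to compound 2, with the place described in the same words for both pairs. On that basis a step of about the size seen from compound 1 to compound 2, a 3.6-fold lower number from compound 1 to compound 2 (0.56 log units; beyond the scatter), is expected again, so the expected step from compound 3 to compound 4 is a 3.6-fold lower number from compound 3 to compound 4 (0.55 log units; beyond the scatter) in this assay. Within the data shown here, with only one measured pair to rest on, the range allowed is wide. Compound 4 is accordingly estimated at 14000 nM in this assay, between 6000 nM and 35000 nM.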

Compound 4, concentration for 50% growth inhibition: 24000 nM
Compound 4: the middle estimate sits 1.7-fold (0.23 log units) below what was measured, and the stated range covers the measured number.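

In this assay, cyclohexyl in place of heptyl on a saturated ring carbon again goes in the direction of stronger inhibition of growth on the second core, giving a 2.1-fold lower number from compound 3 to compound 4 (0.32 log units; beyond the scatter). The two steps point the same way, and their sizes cannot be told apart: the same change on two cores in this assay, a 3.6-fold lower number (0.56 log units; beyond the scatter) from compound 1 to compound 2 and a 2.1-fold lower number (0.32 log units; beyond the scatter) from compound 3 to compound 4, 1.7-fold (0.24 log units) apart, within the scatter of two such steps. Among these compounds, this supports carrying the change between these two cores in this one assay, but it rests on only two pairs, so it does not establish a rule for other cores and does not explain why the step occurs.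

The compounds shown leave open how a phenyl ring, a shorter chain or a chain ending in an amine would behave in the same place on either core. Also open, as far as these compounds go, is whether the step would keep its size with a bromo group in place of the chloro group.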